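Swapping the N-aryl halogen pattern on a pyrazole series

The source may report more compounds than this note shows. Statements on the series, on what has been measured and on what is new or still open speak of the compounds shown alone.

Measured compounds:
compound 1 `Cc1ccccc1-n1cc(-c2ccccc2)c(-c2ccc3c(c2)NC(=O)CO3)n1` gives 94.8% in a functional assay on A549 cells (Homo sapiens) for cytotoxicity, read by colorimetric assay and MTT assay, with a stated time of 3 days, tested at 1 uM; a higher number here means a weaker effect of the compound at the concentration tested, a lower number a stronger effect
compound 2 `O=C1COc2ccc(-c3nn(-c4ccc(Cl)cc4)cc3-c3ccccc3)cc2N1` gives 84.4%

Compound 2 has the lowest of the two numbers, with compound 1 the nearest. For the measured compounds named here, the only measured step, a number 10.4 percentage points lower from compound 1 to compound 2 (beyond the scatter), came from a change on an aromatic nitrogen of the shared core. Compound 3 `O=C1COc2ccc(-c3nn(-c4cc(Cl)cc(Cl)c4)cc3-c3ccccc3)cc2N1` differs from compound 2 by 3,5-dichlorophenyl in place of 4-chlorophenyl on an aromatic nitrogen. Going by the values given here, no step with this change has been measured, so the expected step is uncertain and small, a number 6.4 percentage points lower from compound 2 to compound 3 (within the scatter). For compound 3 the estimate is 78%, within 60% to 95%.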

Compound 3, a percentage reported as activity, at one concentration (the size of the read-out at that concentration, not a potency): 93.1%
Beside the measured number, compound 3's estimate is 15.1 percentage points below it, within the range that was stated.
By their numbers in this assay, from the lowest: compounds 2, 3 and 1 (each within the scatter of the next, the first and the last beyond it).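

Replacing 4-chlorophenyl with 3,5-dichlorophenyl on this aromatic nitrogen gives a number 8.7 percentage points higher from compound 2 to compound 3 (within the scatter) in this assay and so does not separate the two groups, despite the second chlorine. Replacing 2-methylphenyl with 3,5-dichlorophenyl gives a number 1.7 percentage points lower from compound 1 to compound 3 (within the scatter) and does not separate those groups either. No measurement here explains these numbers.

Still open, going by these compounds, is whether an amine or a carboxylic acid on this aryl ring would give a step beyond the scatter. On these data alone, whether these close readings hold at other concentrations also remains unknown.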